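A few compounds are considered here, and "the series" means these few. Any claim that something is new, unique, unknown or untested is made for them only; others in the source may bear on it.

Measured in a functional assay on B16 cells (Mus musculus) for cytotoxicity, read by CCK-8 assay, with a stated time of 24 h; on this read-out higher numbers stand for weaker inhibition and lower numbers for stronger inhibition:
- compound 1 `COc1ccccc1Oc1c(N)nc(-c2ccc(C)cc2)nc1OCCO`: 8430 nM
- compound 2 `COc1ccc(-c2nc(N)c(Oc3ccccc3OC)c(OCCO)n2)cc1`: 18100 nM
- compound 3 `COc1ccccc1Oc1c(N)nc(-c2ccccc2F)nc1OCCO`: 11800 nM

Compound 3 stands in the middle of these three numbers, and neither of its steps leaves the scatter: a 1.4-fold higher number from compound 1 to compound 3 (0.15 log units; within the scatter) and a 1.5-fold lower number from compound 2 to compound 3 (0.19 log units; within the scatter). Compound 4 `COc1ccccc1Oc1c(N)nc(-c2cccc(Br)c2)nc1OCCO` has 3-bromophenyl in place of 2-fluorophenyl on an aromatic carbon between two ring nitrogen atoms (3-bromophenyl in place of 2-fluorophenyl on an aromatic carbon). All three measured steps change the group at this same place. The largest is a 2.1-fold higher number from compound 1 to compound 2 (0.33 log units; beyond the scatter), which is only a modest step, and the other two stay within the scatter. Among the measured compounds shown here, no measured compound carries bromine, so the data give no direct reading of this group. On this evidence, no step beyond the scatter is expected in this assay, and no direction can be firmly assigned. The expected change is a 1.2-fold lower number from compound 3 to compound 4 (0.07 log units; within the scatter). Compound 4 is estimated at 10000 nM, with an expected range of 5000 nM to 20000 nM.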

Compound 4, half-maximal inhibitory concentration: 21900 nM
Compound 4: the middle estimate sits 2.2-fold (0.34 log units) below what was measured; measured number outside the range, above it.
By their numbers in this assay, from the lowest: compounds 1, 3, 2 and 4 (each within the scatter of the next, the first and the last beyond it).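

With bromine at this place, on the aromatic carbon between two ring nitrogen atoms, a second step beyond the scatter appears, a 2.6-fold higher number from compound 1 to compound 4 (0.41 log units; beyond the scatter), and like the earlier one it starts from the 4-methylphenyl group of compound 1. The other two steps stay within the scatter, a 1.9-fold higher number from compound 3 to compound 4 (0.27 log units; within the scatter) and a 1.2-fold higher number from compound 2 to compound 4 (0.08 log units; within the scatter), which leaves compound 4 not distinguishable from compound 2 or compound 3, and the change from 2-fluorophenyl to 3-bromophenyl gives no firm direction on its own. Nothing in the data accounts for these steps.

Going by these compounds, whether 2-bromophenyl or 4-bromophenyl would read like 3-bromophenyl stays open, as does the effect of an amine or a carboxylic acid on that phenyl ring. The 2-hydroxyethoxy and 2-methoxyphenoxy groups are the same in all four compounds, and a longer chain in place of 2-hydroxyethoxy has no reading here.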